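A few compounds are considered here, and "the series" means these few. Any claim that something is new, unique, unknown or untested is made for them only; others in the source may bear on it.

Going by the values given here, compound 1 `CN(C)CN1C(=O)C(=O)c2c(Br)cccc21` is one of three compounds measured in a functional assay on MDA-MB-468 cells (Homo sapiens) for cytotoxicity, read by sulforhodamine B assay, with a stated time of 48 h; on this read-out higher numbers stand for weaker inhibition of growth and lower numbers for stronger inhibition of growth. Compound 1 gives 49000 nM, the second highest of the three numbers; compound 3 `O=C1C(=O)N(CN(c2ccccc2)c2ccccc2)c2cccc(Br)c21` gives 63300 nM, within the scatter of compound 1, while compound 2 `CCN(CC)CN1C(=O)C(=O)c2c(Br)cccc21` gives 11700 nM. Among the compounds with values here, the only single-point step measured so far, a 4.2-fold lower number from compound 1 to compound 2 (0.62 log units; beyond the scatter), alters the amine and not the halogen, so it does not bear on the change considered here. Compound 4 `CN(C)CN1C(=O)C(=O)c2c(Cl)cccc21` differs from compound 1 by chloro in place of bromo on an aromatic carbon. Within the data shown here, with no measured step touching the halogen, no change beyond the scatter is expected, and the expected step is a 1.1-fold higher number from compound 1 to compound 4 (0.05 log units; within the scatter). Compound 4 is therefore expected to give 55000 nM, within a range from 20000 nM to 150000 nM.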

Compound 4, concentration for 50% growth inhibition: 107000 nM
Beside the measured number, compound 4's estimate is 1.9-fold (0.29 log units) below it; measured number inside the range.
By their numbers in this assay, from the lowest: compound 2; then compounds 1, 3 and 4 (each within the scatter of the next, the first and the last beyond it).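

Swapping the halogen on this aromatic carbon is not neutral in this assay: chloro in place of bromo gives a 2.2-fold higher number from compound 1 to compound 4 (0.34 log units; beyond the scatter) and so weaker inhibition of growth, though the step is modest. A change of one atom at this position is therefore enough to move the number beyond the scatter. No measurement at hand accounts for this step. Still open, as far as these compounds go, is where fluoro or a methyl group at this position would fall, and whether chloro in place of bromo would act the same way alongside the diethylamino group of compound 2.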